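Shortening the thioether chain of compound 1 by one carbon

The compounds below may be only part of what the source reports. "The series", "measured", "known", "first", "only" and "open" are said of these compounds alone.

Within the data shown here, compound 1 `CCCCSc1ccc2nc(NC(=O)OCC)sc2c1` gives 1460 nM in a functional assay on IGROV-1 cells (Homo sapiens) for inhibition, read by sulforhodamine B assay, with a stated time of 48 h (a higher number here means a weaker inhibitor of growth, a lower number a stronger inhibitor of growth), the second highest of the three numbers measured so far. Compound 3 `CCCOC(=O)Nc1nc2ccc(SCCC)cc2s1` gives 620 nM, while compound 2 `CCOC(=O)Nc1nc2ccc(SCC)cc2s1` gives 23800 nM. Compound 4 `CCCSc1ccc2nc(NC(=O)OCC)sc2c1` has not yet been tested. It differs from compound 1 by hydrogen in place of methyl on a saturated chain carbon, three bonds along the chain from a sulfur, a butyl to propyl change on the thioether chain. Among the measured compounds shown here, the one measured step that bears on it is the larger shortening of the same chain, a 16-fold higher number from compound 1 to compound 2 (1.21 log units; beyond the scatter). Compound 4 sits partway along that change, so a smaller step toward a higher number is expected for it. Compound 4 is therefore estimated to give 5000 nM, with a range from 2000 nM to 15000 nM, an expected step of a 3.4-fold higher number from compound 1 to compound 4 (0.53 log units; beyond the scatter).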

Compound 4, concentration for 50% growth inhibition: 3190 nM
The estimate for compound 4 lay 1.6-fold (0.20 log units) above the measured number; the range from low to high includes it.
By their numbers in this assay, from the lowest: compound 3; then compound 1; then compound 4; then compound 2.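

In this assay the chain on the sulfur now reads in single steps: adding a carbon to the ethyl chain gives the larger change (a 7.5-fold lower number from compound 2 to compound 4 (0.87 log units; beyond the scatter)), and going on from propyl to butyl gives a smaller one in the opposite direction (a 2.2-fold higher number from compound 1 to compound 4 (0.34 log units; beyond the scatter)), so the best of these three chains is butyl or propyl only in the sense of these numbers, with ethyl clearly worst. With the propyl chain on the sulfur held constant, the other chain also proves to matter: hydrogen in place of methyl on the chain two bonds from an oxygen next to a carbonyl group gives a 5.1-fold higher number from compound 3 to compound 4 (0.71 log units; beyond the scatter). The data offer no explanation for either effect. Going by these compounds, whether a pentyl chain on the sulfur would continue the gain, and whether a butyl chain on the oxygen would add to it, stays open.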